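A few compounds are considered here, and "the series" means these few. Any claim that something is new, unique, unknown or untested is made for them only; others in the source may bear on it.

Series notes. Compound 1 `Nc1scc(CN2CCN(c3ccccc3F)CC2)c1C(=O)c1ccc(Cl)cc1` gives -15% in a functional assay on CHO cells with adenosine receptor A1 (Homo sapiens) as the target, read by cAMP accumulation and immunoassay, with a stated time of 6 min, tested at 10 uM; a lower number here means a stronger effect, a higher number a weaker effect of the compound at the concentration tested. Compound 2 `Nc1scc(CN2CCN(c3ccc(F)cc3F)CC2)c1C(=O)c1ccc(Cl)cc1` gives -82% in this assay, and compound 3 `Nc1scc(CN2CCN(c3cc(F)ccc3F)CC2)c1C(=O)c1ccc(Cl)cc1` gives -80% there. On these numbers compound 3 stands second highest of the three, close to compound 2 and far from compound 1. Both fluoro additions were large: a number 67 percentage points lower from compound 1 to compound 2 (beyond the scatter) and a number 65 percentage points lower from compound 1 to compound 3 (beyond the scatter). By contrast, a number 2 percentage points higher from compound 2 to compound 3 (within the scatter). Compound 4 `Nc1scc(CN2CCN(c3cccc(Cl)c3)CC2)c1C(=O)c1ccc(Cl)cc1` differs from compound 3 by 3-chlorophenyl in place of 2,5-difluorophenyl on an amine nitrogen in a ring. For the measured compounds named here, only the step from compound 2 to compound 3 changes the group on the same ring nitrogen, and it was flat, but no measured step exchanges two fluorines for one chlorine; compound 1 shows that a single halogen on this ring can sit far weaker. The expected step is therefore uncertain and leans toward a higher number, a number 35 percentage points higher from compound 3 to compound 4 (beyond the scatter). For compound 4 the estimate is -45%, expected between -85% and -5%.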

Compound 4, a percentage reported as activity, at one concentration (the size of the read-out at that concentration, not a potency): -77%
Estimate against measurement, compound 4: 32 percentage points above; measured number inside the range.
By their numbers in this assay, from the lowest: compounds 2, 3 and 4 (each within the scatter of the next); then compound 1.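

At this position on the amine nitrogen in a ring, 3-chlorophenyl reads the same as either difluorophenyl group (a number 3 percentage points higher from compound 3 to compound 4 (within the scatter); a number 5 percentage points higher from compound 2 to compound 4 (within the scatter)), so the second fluorine is not required for the stronger effect in this assay. One chlorine on the phenyl ring suffices, and 2-fluorophenyl in compound 1 is the exception among the single-halogen groups (a number 62 percentage points lower from compound 1 to compound 4 (beyond the scatter)). Nothing at hand explains why these groups read as they do.

Still open, on these data alone, is whether a halogen is needed at all, as a methyl or methoxy group in place of the chlorine would show. Also open, as far as these compounds go, is how 2-chlorophenyl or 3-fluorophenyl would read.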